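From 3-hydroxypropyl to vinyl on the shared core

The compounds below may be only part of what the source reports. "The series", "measured", "known", "first", "only" and "open" are said of these compounds alone.

Measured compounds:
- compound 1, `C#CC[C@@H]1O[C@H](COCc2ccccc2)[C@@H](OCc2ccccc2)[C@H](OCc2ccccc2)[C@H]1O`: "not active" (no number reported)
- compound 2, `OCCC[C@@H]1O[C@H](COCc2ccccc2)[C@@H](OCc2ccccc2)[C@H](OCc2ccccc2)[C@H]1O`: 19300 nM

Both compounds were tested in a functional assay on HL-60 cells (Homo sapiens) for antiproliferative activity, read by MTT assay; a lower number here means a stronger inhibitor, a higher number a weaker inhibitor. Compound 1 was reported as "not active" (no number reported), without a number. Among the compounds with values here, compound 2 gives 19300 nM, the only numeric reading in this set, so it is the sole point of reference and a weak inhibitor by any standard. Compound 3, `C=C[C@@H]1O[C@H](COCc2ccccc2)[C@@H](OCc2ccccc2)[C@H](OCc2ccccc2)[C@H]1O`, has not yet been measured. It differs from compound 2 in one place: vinyl in place of 3-hydroxypropyl on a saturated ring carbon. Within the data shown here, no pair of measured compounds gives a step to lean on; compound 1, which also lacks the hydroxy-bearing chain, was reported as not active, so losing the hydroxyl and two chain carbons seems more likely to cost than to gain. Compound 3 is therefore expected to be weaker in this assay, with an estimate of 40000 nM in a range from 12000 nM to 130000 nM. The expected step is a 2.1-fold higher number from compound 2 to compound 3 (0.32 log units; beyond the scatter), probably not far beyond the usual scatter, with a real chance that no number is reported at all.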

Compound 3, half-maximal inhibitory concentration: 11800 nM
Beside the measured number, compound 3's estimate is 3.4-fold (0.53 log units) above it, outside the stated range (below it).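

In this assay, the step is a 1.6-fold lower number from compound 2 to compound 3 (0.21 log units; within the scatter), so these two compounds cannot be told apart, even though the group at this position shrinks from 3-hydroxypropyl to vinyl. The hydroxy group on the chain is therefore not needed for a measurable reading here, since compound 3, whose vinyl group has no hydrogen-bond donor, still gives 11800 nM. No measurement shown here explains this result.

Compound 1, which carries a different small chain at the same position, is reported as "not active" (no number reported), so it remains open why that chain gives no number while vinyl does. As far as these compounds go, it is also open whether an amine, a carboxylic acid or a longer chain at this position would give a clearly lower number than compound 2 and compound 3.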